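Series notes: the step from compound 3 to compound 4

The source may hold more compounds than are shown below. What is called first, only, known or untested is meant among the compounds shown, and "the series" means these compounds.

Three compounds on a shared core have numbers in an ADME assay on microsomes from liver (Mus musculus) for metabolic stability, read by LC-MS, using NADPH, with a stated time of 45 min, tested at 0.5 uM; a lower number here means slower removal, a higher number faster removal of the compound. Compound 1 `COc1ccc2oc(SCCC(=O)N3CCCC3)nc2c1` gives 198 mL/min/g. Compound 2 `Clc1ccc2oc(SCCCN3CCCC3)nc2c1` gives 10.4 mL/min/g. Compound 3 `O=C(CCSc1nc2cc(F)c(F)cc2o1)N1CCCC1` gives 45.9 mL/min/g. Compound 3 stands second highest of the three: compound 1 sits higher, beyond the scatter, and compound 2 sits lower, also beyond the scatter, so compound 3 lies between the two measured ends of the set.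

Compound 4 `O=C(CCSc1nc2cc(F)ccc2o1)N1CCCC1` is not yet measured in this assay. It differs from compound 3 in one place: hydrogen in place of fluoro on an aromatic carbon. Among the measured compounds shown here, no pair of measured compounds shows this same change, so no measured step can be carried over, and the spread of the three numbers is the only guide. With the nearer number belonging to compound 1 at 198 mL/min/g and the farther one to compound 2 at 10.4 mL/min/g, the estimate stays near the middle of the set. The step is expected to be small, tending toward a somewhat higher number, and is estimated as a 1.3-fold higher number from compound 3 to compound 4 (0.12 log units; within the scatter). Compound 4 is expected to give 60 mL/min/g in this assay, within an estimated range of 25 mL/min/g to 140 mL/min/g.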

Compound 4, intrinsic clearance in a liver preparation (reported as CLH), per the amount of preparation that the assay uses: 115 mL/min/g
Compound 4: the middle estimate sits 1.9-fold (0.28 log units) below what was measured; the range from low to high includes it.
By their numbers in this assay, from the lowest: compound 2; then compound 3; then compounds 4 and 1 (each within the scatter of the next).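

In this assay, hydrogen in place of fluoro on the aromatic carbon ortho to a fluoro group gives a 2.5-fold higher number from compound 3 to compound 4 (0.40 log units; beyond the scatter), the first step read at this position, modest in size and beyond the scatter, so the read-out responds to this single change on the shared core. The second step, fluoro in place of methoxy on an aromatic carbon, gives a 1.7-fold lower number from compound 1 to compound 4 (0.24 log units; within the scatter), which lies within the scatter, so compound 1 and compound 4 cannot be told apart in this read-out despite the different group. Nothing among the measurements shown accounts for either step.

The compounds shown leave open what a nitrile, a methyl group or a trifluoromethyl group on this same aromatic carbon would give, since fluoro and hydrogen are the only two groups compared there. They also leave open whether hydrogen in place of fluoro gives a step of similar size when the core carries the chain of compound 2 instead of the chain ending in the pyrrolidine amide.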